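This account rests on a few compounds, and the source may have more. Where it says the series, first, only, none or still open, it means among the compounds named here.

Among the compounds with values here, in a functional assay on A-375 cells (Homo sapiens) for antiproliferative activity, with a stated time of 72 h (on this read-out higher numbers stand for weaker inhibition and lower numbers for stronger inhibition), compound 1 (`C=C[C@@H]1C[C@@H](Cc2ccc(OC)c(O)c2)[C@H]2C(=O)C=CC(=C)[C@H]21`) gives 0.4 nM, the lowest of the two numbers so far. Compound 2 (`C=C1C=CC(=O)[C@@H]2[C@H](Cc3ccccc3)CC[C@H]12`) gives 237 nM, and the gap between the two lies beyond the scatter. Compound 3 (`C=C1C=CC(=O)[C@@H]2[C@H](Cc3ccc(OC)c(O)c3)CC[C@H]12`) has not yet been measured. It departs from compound 1 at one place, with hydrogen in place of vinyl on a saturated ring carbon. Within the data shown here, no measured pair isolates this change, so its size has no direct precedent. In this assay, a step towards a higher number, meaning weaker inhibition, is expected to lie beyond the scatter. Compound 2 also has hydrogen on that carbon and gives 237 nM, which serves as a rough guide to the upper end of the expectation. The full gap is not expected to be reached, so compound 3 is expected to fall between the two measured numbers. The estimated change is a 30-fold higher number from compound 1 to compound 3 (1.48 log units; beyond the scatter). For compound 3 the expected value is 12 nM, with an estimated range of 1.5 nM to 100 nM.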

Compound 3, half-maximal inhibitory concentration: 1.07 nM
The estimate for compound 3 lay 11-fold (1.05 log units) above the measured number; measured number below the stated range.
By their numbers in this assay, from the lowest: compound 1; then compound 3; then compound 2.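

In this assay, hydrogen in place of vinyl on a saturated ring carbon of the five-membered non-aromatic ring gives a 2.7-fold higher number from compound 1 to compound 3 (0.43 log units; beyond the scatter), a modest step that still lies beyond the scatter. Within the data shown here, this is the first direct reading of this position: with vinyl gone, along with its 2 heavy atoms and its double bond outside aromatic rings, compound 3 still gives 1.07 nM, so the vinyl group accounts for only a small part of the activity of compound 1 on this read-out. Nothing available explains the size of this step.

At this carbon the compounds shown compare only vinyl and hydrogen, so the effect of an ethyl group, a longer chain, a hydroxymethyl group or an amine there remains open, and ethyl in particular would help separate the two carbons of vinyl from its double bond. Among these compounds, also open is whether the step keeps its size when the methoxy and hydroxy groups on the aromatic ring are changed, since the only direct pair carries both groups.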